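This account rests on a few compounds, and the source may have more. Where it says the series, first, only, none or still open, it means among the compounds named here.

Measured compounds in this series:
- Compound 1 `COc1ccc(/C=C/C(=O)NCc2ccc(OCc3nc(C)c(C)nc3C)c(OC)c2)cc1O` gives 8560 nM in a functional assay on SH-SY5Y cells (Homo sapiens) for cytotoxicity, read by MTT assay, with stated times of 24 h and 4 h; a lower number here means that less compound is needed, a higher number that more compound is needed for the effect.
- Compound 2 `COc1ccccc1/C=C/C(=O)NCc1ccc(OCc2nc(C)c(C)nc2C)c(OC)c1` gives 7150 nM in this assay.
- Compound 3 `COc1ccc(OC)c(/C=C/C(=O)NCc2ccc(OCc3nc(C)c(C)nc3C)c(OC)c2)c1` gives 11000 nM in this assay.

Compound 3 carries the highest of the three numbers, but its nearest neighbour is compound 1 and its furthest is compound 2, and both gaps lie within the scatter, so no order among the three can be claimed. All three share the same amide-linked core and differ only in the substitution of the aryl ring on the double-bonded chain carbon.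

Compound 4 `COc1cc(OC)c(OC)cc1/C=C/C(=O)NCc1ccc(OCc2nc(C)c(C)nc2C)c(OC)c1` is the next member. Its difference from compound 3 is methoxy in place of hydrogen on an aromatic carbon. The step that bears most directly on it is a 1.5-fold higher number from compound 2 to compound 3 (0.19 log units; within the scatter), which is the same kind of change, a methoxy entering in place of an aromatic hydrogen, and stays within the scatter. The other two steps, a 1.2-fold lower number from compound 1 to compound 2 (0.08 log units; within the scatter) and a 1.3-fold higher number from compound 1 to compound 3 (0.11 log units; within the scatter), also stay within the scatter, so none of the aryl variations seen so far has moved the number beyond noise.

On that basis compound 4 is expected to show a 1.1-fold higher number from compound 3 to compound 4 (0.04 log units; within the scatter), that is, no step beyond the scatter in this assay. The estimate for compound 4 is 12000 nM, with a range from 6000 nM to 25000 nM.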

Compound 4, half-maximal effective concentration: 3620 nM
Estimate against measurement, compound 4: 3.3-fold (0.52 log units) above, and the stated range ends above it.
By their numbers in this assay, from the lowest: compounds 4, 2, 1 and 3 (each within the scatter of the next, the first and the last beyond it).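

In this assay, a methoxy group added at this aromatic carbon, para to a large group, ortho to a methoxy group and meta to a methoxy group, gives a 3.0-fold lower number from compound 3 to compound 4 (0.48 log units; beyond the scatter) and so passes the scatter, if modestly, whereas the same kind of change in a 1.5-fold higher number from compound 2 to compound 3 (0.19 log units; within the scatter) does not. The 2,4,5-trimethoxyphenyl group also clears the scatter against 3-hydroxy-4-methoxyphenyl, with a 2.4-fold lower number from compound 1 to compound 4 (0.37 log units; beyond the scatter) as the step, but not against 2-methoxyphenyl, where a 2.0-fold lower number from compound 2 to compound 4 (0.30 log units; within the scatter) stays within it, so compound 4 separates from compound 1 and compound 3 but not from compound 2. Adding methoxy groups therefore gives no steady trend across the series, with compound 2 and compound 3 both going against one, and no measurement here bears on the reason for this step.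

Open, from the compounds shown here alone, is whether methoxy at this carbon gives the same step without the other two methoxy groups of compound 4 present. Also open, going by these compounds, is how an amine, a hydroxy group or a longer chain such as ethoxy would read at the same carbon.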